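The source may report more compounds than this note shows. Statements on the series, on what has been measured and on what is new or still open speak of the compounds shown alone.

In a functional assay on V79-379A cells (Cricetulus griseus) for cytotoxicity, read by MTT assay, in the presence of a further agent that is not named here (on this read-out lower numbers stand for stronger inhibition and higher numbers for weaker inhibition), compound 3 `COC1=CC(=O)c2c(c(COC(C)=O)c(C)n2C)C1=O` gives 2500 nM. Compound 1 `COC1=CC(=O)c2c(c(COC(=O)c3ccccc3F)c(C)n2C)C1=O` gives 2000 nM, and the pair shows a 1.3-fold higher number from compound 1 to compound 3 (0.10 log units; within the scatter). Compound 2 `COC1=CC(=O)c2c(c(COC(=O)c3ccc(F)cc3)c(C)n2C)C1=O` sits clearly lower at 300 nM.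

Compound 4 `COC1=CC(=O)c2c(c(COc3ccc(F)cc3)c(C)n2C)C1=O` carries 4-fluorophenyl in place of acetyl on an oxygen on a saturated carbon. The closest guide is an 8.3-fold higher number from compound 2 to compound 3 (0.92 log units; beyond the scatter), where 4-fluorophenyl is exchanged for methyl on a carbonyl carbon. Two other steps urge caution: a 1.3-fold higher number from compound 1 to compound 3 (0.10 log units; within the scatter) shows that the 2-fluorophenyl group brings no gain over methyl, and a 6.7-fold lower number from compound 1 to compound 2 (0.82 log units; beyond the scatter) separates the two fluorophenyl groups. Within the data shown here, no measured compound carries 4-fluorophenoxy, so the 4-fluorophenyl gain may only partly transfer.

In this assay, a modest move to a lower number is expected, smaller than the move seen with compound 2 at 300 nM. The expected step is a 3.1-fold lower number from compound 3 to compound 4 (0.49 log units; beyond the scatter). For compound 4 the estimated value is 800 nM, with an expected range from 200 nM to 3000 nM.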

Compound 4, half-maximal inhibitory concentration: 850 nM
Estimate against measurement, compound 4: 1.1-fold (0.03 log units) below, within the range that was stated.
By their numbers in this assay, from the lowest: compound 2; then compound 4; then compounds 1 and 3 (each within the scatter of the next).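

Acetoxy to 4-fluorophenoxy on the saturated carbon gives a 2.9-fold lower number from compound 3 to compound 4 (0.47 log units; beyond the scatter) in this assay. Among these compounds, all earlier compounds kept a carbonyl on this oxygen, so this is the first sign that the carbonyl is not needed for a number lower than that of compound 3, provided an aryl group sits directly on the oxygen. Compound 2 gives 300 nM and compound 4 gives 850 nM, so the carbonyl-free link does not match the best value in the set, and no measured property accounts for the step.

From the compounds shown here alone, whether the fluorine matters on the ether remains open, as a plain phenoxy or a 2-fluorophenoxy group would test this. Also open, going by these compounds, is how an amine or a longer alkoxy chain would behave at this position.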